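Halogenated benzyl swap: from compound 1 to compound 3

This account rests on a few compounds, and the source may have more. Where it says the series, first, only, none or still open, it means among the compounds named here.

Compound 1 `COc1ccc(/C=C2\CN(C(=S)SCc3cn(Cc4ccccc4Cl)nn3)C/C(=C\c3ccc(OC)cc3)C2=O)cc1` is the reference. In a functional assay on DU-145 cells (Homo sapiens) for cytotoxicity, read by MTT assay, with a stated time of 24 h (on this read-out higher numbers stand for weaker inhibition and lower numbers for stronger inhibition), compound 1 gives only a limit, > 80000 nM, not a number. It stands at the limit of > 80000 nM in this assay, at which 1 of the 2 values shown sits. Among the compounds with values here, compound 2 `Cc1ccc(/C=C2\CN(Cc3cn(Cc4cccc(Cl)c4)nn3)C/C(=C\c3ccc(C)cc3)C2=O)cc1` differs from compound 1 in more than one place, so no single step joins the two and its value only shows where a related compound lands. In this assay compound 2 gives 33100 nM. Compound 3 `COc1ccc(/C=C2\CN(C(=S)SCc3cn(Cc4ccc(F)cc4)nn3)C/C(=C\c3ccc(OC)cc3)C2=O)cc1` differs from compound 1 by 4-fluorophenyl in place of 2-chlorophenyl on a saturated chain carbon bound to an aromatic nitrogen. Within the data shown here, no measured step of this kind exists in the set. Compound 3 is expected to stay near the limit, with a step of an at least 1.3-fold lower number from compound 1 to compound 3 (0.12 log units; that floor lies within the scatter) not expected to reach beyond the scatter. The estimate for compound 3 is 60000 nM, within 20000 nM to 100000 nM.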

Compound 3, half-maximal inhibitory concentration: 74600 nM
Compound 3: the middle estimate sits 1.2-fold (0.09 log units) below what was measured; low and high end bracket the measured number.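

In this assay, the 2-chlorobenzyl to 4-fluorobenzyl change on the core of compound 1 gives a step that can be read only as an at least 1.0-fold lower number from compound 1 to compound 3 (0.03 log units; that floor lies within the scatter). Compound 3 thus gives a number at this position, but no real gain over compound 1 can be claimed. The value of compound 1 is a limit, so the step has only a floor: the limit of > 80000 nM in this assay, at which 1 of the 3 values shown sits.

The halogen and its place on the ring change together in this swap, so neither can be credited separately. From the compounds shown here alone, how an amine or a carboxylic acid in place of the halogen would read remains open.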